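Swapping the aryl ketone on two closely related cores

This account rests on a few compounds, and the source may have more. Where it says the series, first, only, none or still open, it means among the compounds named here.

Compound 1 `COC(=O)C1=C(N)Oc2c(OC)cc(Br)cc2C1CC(=O)c1ccc(Cl)cc1` and compound 2 `COC(=O)C1=C(N)Oc2c(OC)cc(Br)cc2C1CC(=O)c1cccc(OC)c1` share one core and differ only in the aryl group on the ketone. In a functional assay on MCF7 cells (Homo sapiens) for antiproliferative activity, read by sulforhodamine B assay, with a stated time of 72 h, tested at 30 uM (on this read-out lower numbers stand for a stronger effect and higher numbers for a weaker effect at the one concentration tested), compound 1 gives 33.8%, and compound 2 gives 94.9%. The change between them is 3-methoxyphenyl in place of 4-chlorophenyl on a carbonyl carbon and the step it made was a number 61.1 percentage points higher from compound 1 to compound 2 (beyond the scatter).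

Compound 3 `COc1cc(Br)cc2c1OC(N)=C(C#N)C2CC(=O)c1ccc(Cl)cc1` carries the same aryl ketone as compound 1 but a different core; the difference between the two cores is cyano in place of methoxycarbonyl on a double-bonded ring carbon. In this assay compound 3 gives 33.3%, and the step of a number 0.5 percentage points lower from compound 1 to compound 3 (within the scatter) shows that the change of core, with the 4-chlorophenyl kept, left the read-out essentially where it was.

Compound 4 `COc1cccc(C(=O)CC2C(C#N)=C(N)Oc3c(OC)cc(Br)cc32)c1` has the core of compound 3 and the aryl ketone of compound 2. Its difference from compound 3 is 3-methoxyphenyl in place of 4-chlorophenyl on a carbonyl carbon, the same change that separates compound 1 from compound 2, made at the same place. Since compound 3 and compound 1 sit within the scatter of each other, the expectation for compound 4 rests on the step from compound 1 to compound 2 being repeated on the second core, with the read-out unable to rise much past the level of compound 2. Compound 4 is therefore expected to give about 90% in this assay, between 65% and 103%, which would mean an estimated step of a number 56.7 percentage points higher from compound 3 to compound 4 (beyond the scatter).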

Compound 4, a percentage reported as activity, at one concentration (the size of the read-out at that concentration, not a potency): 33.9%
Estimate against measurement, compound 4: 56.1 percentage points above; measured number outside the range, below it.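

In this assay the change to 3-methoxyphenyl in place of 4-chlorophenyl on a carbonyl carbon did not carry over from the first core to the second, where the step was a number 0.6 percentage points higher from compound 3 to compound 4 (within the scatter), and the size of the change depended on the core it was made on: the same change on two cores in this assay, a number 61.1 percentage points higher (beyond the scatter) from compound 1 to compound 2 and a number 0.6 percentage points higher (within the scatter) from compound 3 to compound 4, 60.5 percentage points apart, beyond the scatter of two such steps

Read the other way, cyano in place of methoxycarbonyl on a double-bonded ring carbon, which left the read-out in place with the 4-chlorophenyl kept, gave a number 61 percentage points lower from compound 2 to compound 4 (beyond the scatter) with the 3-methoxyphenyl present, so the two changes do not simply add up in this set: the same change on two cores in this assay, a number 0.5 percentage points lower (within the scatter) from compound 1 to compound 3 and a number 61 percentage points lower (beyond the scatter) from compound 2 to compound 4, 60.5 percentage points apart, beyond the scatter of two such steps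

This shows a dependence between the two places within these four compounds only; it does not show why that dependence arises, and a read-out at one concentration gives no potency.

From the compounds shown here alone, it remains open whether a 3-chlorophenyl or a 4-methoxyphenyl on the carbonyl carbon would separate the two cores as the 3-methoxyphenyl does. Going by these compounds, it is equally open whether a carboxylic acid or a primary amide on the double-bonded ring carbon would follow the methoxycarbonyl or the cyano.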